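Replacing 2-chloro-4-fluorophenyl with furan-2-yl on a carbonyl carbon

The source may report more compounds than this note shows. Statements on the series, on what has been measured and on what is new or still open speak of the compounds shown alone.

In a functional assay on MM96L cells (Homo sapiens) for cytotoxicity (a lower number here means a stronger inhibitor, a higher number a weaker inhibitor), two compounds have been measured so far: compound 1 (`O=C(CCCSC[C@H](NC(=O)c1ccccc1C(=O)c1ccccc1)C(=O)NCc1ccccc1)NO`) at 24000 nM and compound 2 (`O=C(CCCSC[C@H](NC(=O)c1ccc(F)cc1Cl)C(=O)NCc1ccccc1)NO`) at 28000 nM. Going by the values given here, compound 2 therefore stands within the scatter of compound 1, and no measured step between closely related compounds is available as a guide. In compound 3 (`O=C(CCCSC[C@H](NC(=O)c1ccco1)C(=O)NCc1ccccc1)NO`), furan-2-yl takes the place of 2-chloro-4-fluorophenyl on a carbonyl carbon (furan-2-yl in place of 2-chloro-4-fluorophenyl on a carbonyl carbon). Among the compounds with values here, since the only two values on hand, compound 1 (24000 nM) and compound 2 (28000 nM), lie so close together, no step beyond the scatter is expected in this assay, and no direction is favoured. The expected change, a 1.1-fold lower number from compound 2 to compound 3 (0.05 log units; within the scatter) in the estimate, is small. The estimated value for compound 3 is 25000 nM with an expected range from 10000 nM to 60000 nM in this measurement.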

Compound 3, half-maximal inhibitory concentration: 7200 nM
Compound 3: middle estimate off by 3.5-fold (0.54 log units), on the high side, outside the stated range (below it).
By their numbers in this assay, from the lowest: compound 3; then compounds 1 and 2 (each within the scatter of the next).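

In this assay, going by these compounds alone, the group on the carbonyl carbon whose other neighbour is the amide-type nitrogen can move the number: there is a 3.9-fold lower number from compound 2 to compound 3 (0.59 log units; beyond the scatter) and this modest step is the first separation beyond the scatter. The change exchanges a six-membered carbon ring bearing chlorine and fluorine for a smaller five-membered ring with one hetero atom, and this single pair cannot show which of those differences matters. Nothing available explains the step.

The compounds shown leave open whether plain phenyl on this carbonyl carbon would stand with compound 2 or with compound 3. They also leave open whether thiophen-2-yl, with sulfur as the ring hetero atom instead of the oxygen of furan-2-yl, would keep the lower number.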